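The compounds below may be only part of what the source reports. "The series", "measured", "known", "first", "only" and "open" are said of these compounds alone.

Measured so far in a functional assay on the whole organism (strain albino) with Mus musculus as the target, with a stated time of 4 h; a higher number here means that more compound is needed for the effect, a lower number that less compound is needed:

compound 1 `Cc1ccc(C(=O)N2NC(=O)/C(=C\c3ccc(O)cc3)N=C2c2ccccc2)cc1` gives 100 mg/kg
compound 2 `COc1ccc(/C=C2/N=C(c3ccccc3)N(C(=O)c3ccc(C)cc3)NC2=O)cc1` gives 100 mg/kg

Going by the values given here, compound 1 stands level with compound 2: the only step between them, no change at the digits printed from compound 1 to compound 2 (within the scatter), lies within the scatter of repeated measurements of this kind.

Compound 3 `O=C1NN(C(=O)c2ccc(F)cc2)C(c2ccccc2)=N/C1=C/c1ccc(O)cc1` has not yet been measured. It differs from compound 1 by fluoro in place of methyl on an aromatic carbon. Among the compounds with values here, no measured step bears directly on this exchange; the one step known, from compound 1 to compound 2, concerns a methyl in place of hydrogen on an oxygen and showed no change beyond the scatter. The exchange here swaps one heavy atom for one heavy atom, with no hydrogen-bond donors or acceptors added or removed, so nothing in the data points to a step beyond the scatter. The expected step from compound 1 to compound 3 in this assay is therefore no change at the digits printed from compound 1 to compound 3 (within the scatter). For compound 3 the estimate in this assay is 100 mg/kg, with a range from 50 mg/kg to 200 mg/kg.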

Compound 3, dose for half-maximal effect: "not active" (no number reported)
For compound 3 the study gives words and no number; the estimate stays without a comparison.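

Going by these compounds alone, compound 3 is reported in this assay in words only, so no step from compound 1 to compound 3 can be read. No available evidence accounts for this result. The compounds shown leave open how 4-fluorophenyl in place of 4-methylphenyl affects the dose required.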